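Chloro in place of methyl, from compound 2 to compound 4

The compounds below may be only part of what the source reports. "The series", "measured", "known", "first", "only" and "open" are said of these compounds alone.

Compound 1 `Cc1ccc(Nc2nc(C)c(C(=O)/C=C/c3ccc(Cl)cc3)s2)cc1`, compound 2 `Cc1ccc(Nc2nc(C)c(C(=O)/C=C/c3ccccc3)s2)cc1` and compound 3 `Cc1ccc(Nc2nc(C)c(C(=O)/C=C/c3ccccc3Cl)s2)cc1` share a core and differ only in the aryl group on the double-bonded chain carbon. In a functional assay on NCI-H460 cells (Homo sapiens) for cytotoxicity, read by MTT assay (on this read-out lower numbers stand for stronger inhibition and higher numbers for weaker inhibition), compound 1 gives > 25000 nM, which is a limit of the assay and not a number. In this assay compound 2 gives > 25000 nM, again a limit. In this assay compound 3 gives > 25000 nM, also a limit. Accordingly the steps a step that the two limits leave unreadable from compound 1 to compound 2, a step that the two limits leave unreadable from compound 1 to compound 3 and a step that the two limits leave unreadable from compound 2 to compound 3 cannot be sized; all three values sit at the limit of > 25000 nM in this assay, at which 3 of the 3 values shown sit. Compound 2 thus stands only at that limit, with no number to place it.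

Compound 4 `Cc1nc(Nc2ccc(Cl)cc2)sc1C(=O)/C=C/c1ccccc1` is not yet measured. It differs from compound 2 by chloro in place of methyl on an aromatic carbon. For the measured compounds named here, no measured step touches this part of the structure; the three measured steps concern the aryl group on the chain and are unreadable in any case. With every measured value at the limit, no step beyond the scatter can be foreseen in either direction. Compound 4 is therefore expected to give 30000 nM in this assay, within 12000 nM to 80000 nM, most likely reported as a limit. The expected step is a step that the limit leaves unreadable from compound 2 to compound 4.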

Compound 4, half-maximal inhibitory concentration: > 25000 nM
Compound 4 was reported as a limit (the forecaster's own chance of this, stated with the estimate: 80%); the middle value is on the limit's open side.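

Compound 4 gives > 25000 nM in this assay, a limit and not a number. No size can be read for the step between compound 2 and compound 4, so no new step results: the limit of > 25000 nM in this assay, at which 4 of the 4 values shown sit.

Going by these compounds, whether any change on the shared core gives a measurable value in this assay remains open.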